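Compound 3: propanoyl in place of 1,3-benzothiazol-2-yl

The source may hold more compounds than are shown below. What is called first, only, known or untested is meant among the compounds shown, and "the series" means these compounds.

In a toxicity assay on NIH3T3 cells (Mus musculus) for cytotoxicity, read by resazurin assay (a lower number here means that less compound is needed, a higher number that more compound is needed for the effect), compound 2 (`c1ccc(-c2ccc(Cn3cncc3CNc3ccc(-c4nc5ccccc5s4)c(-c4ccccc4)c3)cc2)cc1`) stands at > 1000 nM as a limit and not a number. Compound 1 (`CNC(=O)c1ccc(NCc2cncn2Cc2ccc(-c3ccccc3)cc2)cc1-c1ccccc1`) also gives only a limit of > 1000 nM in this read-out. Both sit at the same limit (the limit of > 1000 nM in this assay, at which 2 of the 2 values shown sit). Compound 3 (`CCC(=O)c1ccc(NCc2cncn2Cc2ccc(-c3ccccc3)cc2)cc1-c1ccccc1`) carries propanoyl in place of 1,3-benzothiazol-2-yl on an aromatic carbon. Within the data shown here, the one measured step (a step that the two limits leave unreadable from compound 1 to compound 2) changes the same place but has no readable size. No step beyond the scatter is expected in this assay in either direction, and the expected step is small (a step that the limit leaves unreadable from compound 2 to compound 3). Compound 3 is estimated at 2000 nM with an expected range from 1000 nM to 8000 nM and may well return only a limit.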

Compound 3, half-maximal effective concentration: > 10000 nM
Compound 3 was reported as a limit (the forecaster's own chance of this, stated with the estimate: 75%); middle value at least 5.0-fold (0.69 log units) from the limit.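

Among these compounds, compound 1, compound 2 and compound 3 all give only limits in this assay, and no step among them can be read. The compounds shown leave open whether changing the group on this aromatic carbon shifts the read-out at all.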